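The compounds below may be only part of what the source reports. "The series", "measured", "known", "first", "only" and "open" are said of these compounds alone.

Measured so far:
compound 2 `CCN(CC)CCCOc1cc2ncnc(Nc3ccc4sc(C(=O)Nc5c(C)cccc5Cl)cc4c3)c2cc1OC` — 3550 nM
compound 3 `Cc1nc(Nc2ccc3sc(C(=O)Nc4c(C)cccc4Cl)cc3c2)cc(N2CCC(C)CC2)n1` — 22200 nM
compound 1 `Cc1nc(Nc2ccc3sc(C(=O)Nc4c(C)cccc4Cl)cc3c2)cc(N2CCCCC2)n1` — "not determined" (no result reported) in a functional assay on K562 cells (Homo sapiens) for cytotoxicity, read by MTT assay and WST assay, with a stated time of 72 h; on this read-out lower numbers stand for stronger inhibition and higher numbers for weaker inhibition

Compound 3 stands at the highest of the two numbers, and its nearest neighbour, compound 2, lies beyond the scatter below it. Going by the values given here, no two measured compounds differ in one place, so no single step is known. Compound 4 `Cc1nc(Nc2ccc3sc(C(=O)Nc4c(C)cccc4Cl)cc3c2)cc(N2CCN(C)CC2)n1` differs from compound 3 by 4-methylpiperazin-1-yl in place of 4-methylpiperidin-1-yl on an aromatic carbon. Among the compounds with values here, the only lead is that compound 2 gives 3550 nM, the lower number of the two. The expected step of a 2.2-fold lower number from compound 3 to compound 4 (0.35 log units; beyond the scatter) is therefore a drop in number, of a size at the edge of the scatter. Compound 4 is expected to give 10000 nM, within 2500 nM to 40000 nM.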

Compound 4, half-maximal inhibitory concentration: 17000 nM
Compound 4: the middle estimate sits 1.7-fold (0.23 log units) below what was measured, within the range that was stated.
By their numbers in this assay, from the lowest: compound 2; then compounds 4 and 3 (each within the scatter of the next).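

In this assay, going by these compounds alone, 4-methylpiperazin-1-yl in place of 4-methylpiperidin-1-yl on this aromatic carbon gives a 1.3-fold lower number from compound 3 to compound 4 (0.12 log units; within the scatter), the first single-place step. At this position, the second ring nitrogen and the added hydrogen-bond acceptor therefore do not separate the two compounds beyond the scatter. No measurement available here bears on this result.

Open, as far as these compounds go, is whether morpholin-4-yl, a carboxylic acid or a longer chain ending in a primary amine at this position would move the number beyond the scatter.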